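A few compounds are considered here, and "the series" means these few. Any claim that something is new, unique, unknown or untested is made for them only; others in the source may bear on it.

Compound 1, `Cc1cccc(-c2noc([C@H](C)NC(=O)c3cc(C4CC4)n(C)n3)n2)c1`: > 30000 nM
Compound 2, `C[C@H](NC(=O)c1cc(C(F)(F)F)nn1C)c1nc(-c2cccnc2)no1`: 11800 nM

Of the compounds shown here, two sharing a common core have been tested in an assay on T-REx-293 cells for inhibition of potassium channel subfamily T member 1 (Homo sapiens), read by patch clamp; a higher number here means a weaker inhibitor, a lower number a stronger inhibitor. For compound 1 the result is a limit of the assay rather than a number: compound 1 reaches only > 30000 nM. Among the compounds with values here, compound 2 gives 11800 nM in this assay, which makes it the only compound here with a measured number; the one other result sits at the limit of > 30000 nM in this assay, at which 1 of the 2 values shown sits. Both results point to weak inhibition. Within the data shown here, no step between the two is given, as they differ in more than one place.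

Compound 3, `C[C@H](NC(=O)c1cc(C(F)(F)F)nn1C)c1nc(-c2ccnc(C(F)F)c2)no1`, has not yet been measured. It keeps the whole of compound 2 except at one aromatic carbon of the shared core: a group of 9 heavy atoms (6 carbon, 1 nitrogen, 2 fluorine; one six-membered aromatic ring with 1 hetero atom) in place of a group of 6 heavy atoms (5 carbon, 1 nitrogen; one six-membered aromatic ring with 1 hetero atom), on an aromatic carbon. Among the measured compounds shown here, no measured pair shows what such a change does here, so any expectation rests on little. A small gain, or no change beyond the usual scatter, seems the more likely outcome. Compound 3 is expected to give about 8000 nM, within a range from 2000 nM to 30000 nM. This corresponds to an expected step of a 1.5-fold lower number from compound 2 to compound 3 (0.17 log units; within the scatter).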

Compound 3, half-maximal inhibitory concentration: 61 nM
The estimate for compound 3 lay 130-fold (2.12 log units) above the measured number; measured number outside the range, below it.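

One aromatic carbon of the shared core turns out to be a place where a single change can matter greatly: in this assay, replacing pyridin-3-yl with the larger group of 9 heavy atoms gives a 190-fold lower number from compound 2 to compound 3 (2.29 log units; beyond the scatter). Both groups hold one six-membered aromatic ring with 1 hetero atom, and they match in hydrogen-bond donors, hydrogen-bond acceptors and net charge, so those counts alone would not have pointed to a step of this size. Nothing measured here explains why the step is so large.

The compounds shown cannot separate the part played by the fluorine atoms from the rest of the change, and a methyl group, a chlorine atom or a nitrile in place of the fluorine-bearing group would help to tell these apart. They also leave open whether the same group at this position would bring a comparable step on the core of compound 1, which carries a different substituted amide.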